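Cyclobutyl Ether in Place of the Aminoethyl Chain

The source may hold more compounds than are shown below. What is called first, only, known or untested is meant among the compounds shown, and "the series" means these compounds.

Compound 3 `NCCOc1cc(-c2cccnc2)ccc1C(N)=O` gives the lowest number of the three compounds measured in an assay on cells for inhibition of MAP kinase-interacting serine/threonine-protein kinase 1 (Homo sapiens), read by mobility shift assay, with stated times of 10 min and 60 min, in the presence of a further agent that is not named here (a higher number here means a weaker inhibitor, a lower number a stronger inhibitor), namely 820 nM. Compound 1 `CCOc1cc(-c2cccnc2)ccc1C(N)=O` gives 2200 nM in this assay, and compound 2 `NC(=O)c1ccc(-c2cccnc2)cc1OC1CCNC1` gives 1900 nM. Of the measured steps, a 2.7-fold lower number from compound 1 to compound 3 (0.43 log units; beyond the scatter) and a 2.3-fold lower number from compound 2 to compound 3 (0.36 log units; beyond the scatter) are both beyond the scatter, whereas a 1.2-fold lower number from compound 1 to compound 2 (0.06 log units; within the scatter) lies within it.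

Compound 4 `NC(=O)c1ccc(-c2cccnc2)cc1OC1CCC1` differs from compound 3 in one place: cyclobutyl in place of 2-aminoethyl on an oxygen on an aromatic ring. The change takes away the amino that the step of a 2.7-fold lower number from compound 1 to compound 3 (0.43 log units; beyond the scatter) had introduced, and it places a carbon ring on the oxygen, a feature that in compound 2 gave a number close to that of compound 1. The two bearing steps thus point toward a modestly higher number for compound 4 once the amino is gone, a step estimated at a 2.7-fold higher number from compound 3 to compound 4 (0.43 log units; beyond the scatter). Compound 4 is expected to read about 2200 nM in this assay, with a range from 900 nM to 6000 nM.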

Compound 4, half-maximal inhibitory concentration: 1900 nM
The estimate for compound 4 lay 1.2-fold (0.06 log units) above the measured number; low and high end bracket the measured number.
By their numbers in this assay, from the lowest: compound 3; then compounds 2, 4 and 1 (each within the scatter of the next).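

Replacing 2-aminoethyl with cyclobutyl on the oxygen gives a 2.3-fold higher number from compound 3 to compound 4 (0.36 log units; beyond the scatter) in this assay, so the carbon ring does not keep the lower number of compound 3. Set against the other ethers, compound 4 shows no change at the digits printed from compound 2 to compound 4 (within the scatter) and a 1.2-fold lower number from compound 1 to compound 4 (0.06 log units; within the scatter) and so joins ethyl and pyrrolidin-3-yl in one group within the scatter, leaving 2-aminoethyl as the only one of the four substituents that stands apart. Nothing at hand explains why these numbers fall as they do.

On these data alone, it remains open whether the lower number of compound 3 depends on the amine at the end of the chain or on the chain itself. A 2-hydroxyethyl group, a longer chain such as 3-aminopropyl, or a carboxylic acid on the chain could help to separate these possibilities.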